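A Thiophene Swap on the Longer-Chain Amide

This account rests on a few compounds, and the source may have more. Where it says the series, first, only, none or still open, it means among the compounds named here.

Compound 3 `CCCCCCCCCCCCCCNC(=O)[C@@H](NC(=O)c1ccccc1)[C@@H](C)O` is measured in a functional assay on SW-620 cells (Homo sapiens) for cytotoxicity, read by MTT assay, with a stated time of 48 h (on this read-out higher numbers stand for weaker inhibition and lower numbers for stronger inhibition), at 200000 nM. Its shorter-chain counterpart, compound 1 `CCCCCCCCCCCCNC(=O)[C@@H](NC(=O)c1ccccc1)[C@@H](C)O`, gives 200000 nM, and the step of no change at the digits printed from compound 1 to compound 3 (within the scatter). Compound 2 `CCCCCCCCCCCCNC(=O)[C@@H](NC(=O)c1cccs1)[C@@H](C)O`, carrying the thiophen-2-yl group on the shorter chain, gives 29200 nM, and the step of a 6.8-fold lower number from compound 1 to compound 2 (0.84 log units; beyond the scatter). Compound 4 `CCCCCCCCCCCCCCNC(=O)[C@@H](NC(=O)c1cccs1)[C@@H](C)O` differs from compound 3 by thiophen-2-yl in place of phenyl on a carbonyl carbon. For the measured compounds named here, the one measured step of this kind, a 6.8-fold lower number from compound 1 to compound 2 (0.84 log units; beyond the scatter), points to a modest fall in the number, while no change at the digits printed from compound 1 to compound 3 (within the scatter) suggests the longer chain alone does not move the read-out. For compound 4 a similar modest fall is therefore expected, a 6.9-fold lower number from compound 3 to compound 4 (0.84 log units; beyond the scatter). Compound 4 is estimated at 29000 nM, with an expected range from 12000 nM to 75000 nM.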

Compound 4, half-maximal inhibitory concentration: 78400 nM
Compound 4: middle estimate off by 2.7-fold (0.43 log units), on the low side; the measured number lies above the stated range.
By their numbers in this assay, from the lowest: compound 2; then compound 4; then compounds 1 and 3 (each within the scatter of the next).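

In this assay, thiophen-2-yl in place of phenyl on a carbonyl carbon still gives a 2.6-fold lower number from compound 3 to compound 4 (0.41 log units; beyond the scatter), but the change counts for less on the longer chain: the same change on two cores in this assay, a 6.8-fold lower number (0.84 log units; beyond the scatter) from compound 1 to compound 2 and a 2.6-fold lower number (0.41 log units; beyond the scatter) from compound 3 to compound 4, 2.7-fold (0.43 log units) apart, beyond the scatter of two such steps. The longer chain, which left the number unchanged with phenyl, does count with thiophen-2-yl, giving a 2.7-fold higher number from compound 2 to compound 4 (0.43 log units; beyond the scatter): the same change on two cores in this assay, no change at the digits printed (within the scatter) from compound 1 to compound 3 and a 2.7-fold higher number (0.43 log units; beyond the scatter) from compound 2 to compound 4, 2.7-fold (0.43 log units) apart, beyond the scatter of two such steps. In these four compounds, the two changes therefore do not simply add up.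

Still open, going by these compounds, is whether a longer chain would widen this gap, and whether furan-2-yl on the same carbonyl carbon would follow thiophen-2-yl.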